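Growth inhibition across a shared chloropyrimidine-free core series

The compounds below may be only part of what the source reports. "The series", "measured", "known", "first", "only" and "open" are said of these compounds alone.

Three compounds of the series carry a number in an ADME assay on L02 cells (Homo sapiens) for inhibition, read by CCK-8 assay, with a stated time of 48 h; on this read-out higher numbers stand for weaker inhibition of growth and lower numbers for stronger inhibition of growth. Compound 1 `Cc1ccccc1Nc1nc(Nc2cccnc2)ncc1Cl` gives 22900 nM in this assay. Compound 2 `Cc1ccccc1Nc1nc(NCc2ccccc2)ncc1Cl` reaches only the limit > 100000 nM in this assay, which is a limit and not a number, the limit described as the limit of > 100000 nM in this assay, at which 1 of the 3 values shown sits. Among the compounds with values here, the one step measured in one place, an at least 4.3-fold higher number from compound 1 to compound 2 (0.64 log units; beyond the scatter), is the only change with a size on record. Compound 3 `CN1CCN(c2ccc(Nc3ncc(Cl)c(Nc4ccccc4)n3)nc2)CC1` gives 7990 nM in this assay and stands lowest of the two numbers; its gap to compound 1 is beyond the scatter.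

Compound 4 `CN1CCN(c2ccc(Nc3ncc(Cl)c(Nc4ccc(C(C)(C)C)cc4)n3)nc2)CC1` differs from compound 3 by tert-butyl in place of hydrogen on an aromatic carbon. Within the data shown here, no measured step touches that ring or that kind of group: the single step on record concerns a nitrogen on an aromatic ring elsewhere in the shared core, so it gives no direction for the present change. The expectation is therefore no step beyond the scatter, with a 1.0-fold higher number from compound 3 to compound 4 (0.00 log units; within the scatter) as the estimated step. Compound 4 is expected to give 8000 nM in this assay, within 3000 nM to 25000 nM.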

Compound 4, concentration for 50% growth inhibition: 6070 nM
For compound 4 the middle estimate is 1.3-fold (0.12 log units) above the measured one; the measured number falls inside the stated range.
By their numbers in this assay, from the lowest: compounds 4 and 3 (each within the scatter of the next); then compound 1. At a limit, above all of these: compound 2.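

In this assay, tert-butyl in place of hydrogen on the six-membered aromatic ring of carbon only gives a step within the scatter (a 1.3-fold lower number from compound 3 to compound 4 (0.12 log units; within the scatter)), so the two compounds cannot be told apart on this read-out. Within the data shown here, this is the first measured change at this position; the only earlier step concerned the group on a nitrogen elsewhere on the shared core. At this position, therefore, the phenyl to 4-(tert-butyl)phenyl change, which adds 4 heavy atoms, leaves the read-out within the scatter, and no measured property on record bears on this result.

Open, from the compounds shown here alone, is whether an amine, a carboxylic acid or a longer chain at this position would also stay within the scatter of compound 3. Also open, going by these compounds, is whether tert-butyl gives a similar step on the core of compound 1.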